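Oxygen for sulfur on the chain nitrogen of compound 3

A few compounds are considered here, and "the series" means these few. Any claim that something is new, unique, unknown or untested is made for them only; others in the source may bear on it.

Compound 3 `CCCNC(=S)NCCC(O)c1cc(Cl)ccc1N` stands second highest of the three numbers in an assay for inhibition of Nitric oxide synthase, inducible (Homo sapiens), read by scintillation counting, with a stated time of 30 min, tested at 1 mM; on this read-out higher numbers stand for more inhibition at the one concentration tested (going by the name of the read-out) and lower numbers for less inhibition: compound 3 gives 55%, compound 2 `CCNC(=S)NCCC(O)c1cc(Cl)ccc1N` gives 60.4%, and compound 1 `CCCNC(=O)NCCC(O)c1cc(OC)ccc1N` gives 14.7%. Within the data shown here, the only step between measured compounds is a number 5.4 percentage points lower from compound 2 to compound 3 (within the scatter), and it does not touch the change at hand. Compound 4 `CCCNC(=O)NCCC(O)c1cc(Cl)ccc1N` differs from compound 3 by a group of 6 heavy atoms (4 carbon, 1 nitrogen, 1 oxygen; no ring) in place of a group of 6 heavy atoms (4 carbon, 1 nitrogen, 1 sulfur; no ring), on an amine nitrogen. Among the measured compounds shown here, no measured pair isolates this change; compound 1 and compound 3 differ in a second place as well, and their values lie far apart. Because compound 1, which also carries the propylcarbamoyl group, gives 14.7%, a downward step is expected. Compound 4 is therefore estimated at 25%, in a range of 8% to 45%, an expected step of a number 30 percentage points lower from compound 3 to compound 4 (beyond the scatter).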

Compound 4, a percentage reported as inhibition, at one concentration (the size of the read-out at that concentration, not a potency): 19.6%
The estimate for compound 4 lay 5.4 percentage points above the measured number, and the stated range covers the measured number.
By their numbers in this assay, from the lowest: compounds 1 and 4 (each within the scatter of the next); then compounds 3 and 2 (each within the scatter of the next).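

In this assay, oxygen for sulfur on the amine nitrogen is now isolated in a single pair, and the step is large (a number 35.4 percentage points lower from compound 3 to compound 4 (beyond the scatter)); replacing the shorter sulfur-bearing group of compound 2 with propylcarbamoyl gives a similar result (a number 40.8 percentage points lower from compound 2 to compound 4 (beyond the scatter)). Chloro in place of methoxy on an aromatic carbon, by contrast, stays within the scatter (a number 4.9 percentage points higher from compound 1 to compound 4 (within the scatter)). Nothing available explains why the sulfur group and the propylcarbamoyl group differ so much. Still open, going by these compounds, is whether a guanidine on this amine nitrogen would sit nearer compound 3 or compound 4.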